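The source may report more compounds than this note shows. Statements on the series, on what has been measured and on what is new or still open speak of the compounds shown alone.

Measured in a functional assay on HEL cells (Homo sapiens) for inhibition; on this read-out higher numbers stand for weaker inhibition and lower numbers for stronger inhibition:
compound 1 `CC(C)c1cc(-c2n[nH]c(=O)n2-c2cccc(C(=O)NCCCC(=O)NO)c2)c(O)cc1O`: 4600 nM
compound 2 `CC(C)c1cc(-c2n[nH]c(=O)n2-c2ccc(C(=O)NCCCCCCC(=O)NO)cc2)c(O)cc1O`: 4600 nM
compound 3 `CC(C)c1cc(-c2n[nH]c(=O)n2-c2cccc(NC(=O)CCCCCCC(=O)NO)c2)c(O)cc1O`: 1600 nM

Compound 1 stands at the weak end of this small set. Its number is level with that of compound 2, and together they hold the highest value of the three. Compound 3, at 1600 nM, gives a lower number, and its gap to compound 1 lies beyond the usual scatter of repeat measurements.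

The next compound to be tested is compound 4 `CC(C)c1cc(-c2n[nH]c(=O)n2-c2cccc(C(=O)NCCCCC(=O)NO)c2)c(O)cc1O`. It keeps the core of compound 1 and changes only the chain that ends in the hydroxamic acid: (hydroxycarbamoyl)methyl in place of hydroxycarbamoyl on a saturated chain carbon, three bonds along the chain from an amide-type nitrogen. In words, (hydroxycarbamoyl)methyl stands in place of hydroxycarbamoyl on a saturated chain carbon, three bonds along the chain from an amide-type nitrogen. Read one bond further out, this is 3-(hydroxycarbamoyl)propyl to 4-(hydroxycarbamoyl)butyl.

Within the data shown here, no two measured compounds differ in one place only, so the data do not isolate the effect of chain length. Compound 2 has a longer chain but differs in other ways too, and it gives 4600 nM. That gives little reason to expect a large shift in this assay. The expected step, a 1.4-fold lower number from compound 1 to compound 4 (0.16 log units; within the scatter), is small, towards a lower number, and may stay within the scatter. For compound 4 the estimated value is 3200 nM, with an expected range of 1300 nM to 7000 nM.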

Compound 4, half-maximal inhibitory concentration: 4600 nM
Beside the measured number, compound 4's estimate is 1.4-fold (0.16 log units) below it, within the range that was stated.
By their numbers in this assay, from the lowest: compound 3; then compounds 1, 2 and 4 (each within the scatter of the next).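

In this assay, the change from 3-(hydroxycarbamoyl)propyl to 4-(hydroxycarbamoyl)butyl gives no change at the digits printed from compound 1 to compound 4 (within the scatter), and this is the only pair shown that differs in one place. At this spot, on a saturated chain carbon, three bonds along the chain from an amide-type nitrogen, (hydroxycarbamoyl)methyl in place of hydroxycarbamoyl therefore leaves the read-out where it stood, so this single extension of the chain neither gains nor loses inhibition in these cells. The data at hand offer no explanation for this flat result.

The compounds shown leave open whether a shorter chain such as 2-(hydroxycarbamoyl)ethyl, or a longer one such as 5-(hydroxycarbamoyl)pentyl, on the same core would move the number, and whether a carboxylic acid at the chain end could stand in for the hydroxamic acid. Among these compounds, compound 2 and compound 3 differ from these two compounds in more than one place, so no step to either can be read, and what sets compound 3 apart remains unresolved.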